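Bromo for hydrogen on an inactive benzofuranone pair

The source may hold more compounds than are shown below. What is called first, only, known or untested is meant among the compounds shown, and "the series" means these compounds.

Compound 2 `O=c1c([C@@H]2C[C@H](c3ccccc3)ON2c2ccccc2)coc2ccccc12` is the reference point here. In a functional assay on PC-3 cells (Homo sapiens) for inhibition, read by sulforhodamine B assay, with a stated time of 48 h (a lower number here means a stronger inhibitor, a higher number a weaker inhibitor), compound 2 gives > 60000 nM, which is a limit of the assay and not a number. Its close relative compound 1 `Cc1ccc2occ([C@@H]3C[C@H](c4ccccc4)ON3c3ccccc3)c(=O)c2c1` is the other measured member of the series. In this assay compound 1 gives > 60000 nM, again a limit rather than a number. The step that the two limits leave unreadable from compound 1 to compound 2 therefore cannot be sized, since the limit of > 60000 nM in this assay, at which 2 of the 2 values shown sit, holds both values. Compound 3 `O=c1c([C@@H]2C[C@H](c3ccccc3)ON2c2ccccc2)coc2ccc(Br)cc12` carries the change (bromo in place of hydrogen on an aromatic carbon). Going by the values given here, no measured step speaks to that change, and the one step available is unreadable, so the expectation rests on the two limits alone. On that basis the step of a number no higher from compound 2 to compound 3 (the limit leaves the size open) is expected to stay within the scatter, with compound 3 most likely also returning only a limit. Compound 3 is estimated at 60000 nM in this assay, with a range from 20000 nM to 150000 nM.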

Compound 3, half-maximal inhibitory concentration: 60000 nM
Compound 3: the middle estimate sits on the measured number at the digits printed, and the stated range covers the measured number.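

In this assay, going by these compounds alone, compound 3, with bromo on an aromatic carbon of the six-membered aromatic ring of carbon only, gives 60000 nM, the only value in this set that is a number and not a limit. The step of a number no higher from compound 2 to compound 3 (the limit leaves the size open) and the step of a number no higher from compound 1 to compound 3 (the limit leaves the size open) cannot be read, so bromo is not shown to give any real gain over hydrogen or methyl at this position. Compound 1 and compound 2 each stand at a limit, and compound 3 lands on the same figure: the limit of > 60000 nM in this assay, at which 2 of the 3 values shown sit.

Going by these compounds, it remains open how a methoxy, an amine or a carboxylic acid on this carbon would read in this assay. Changes elsewhere on the shared core also remain open, since the three compounds differ only at this carbon.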